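Compound 1 to compound 3: changing the carbonyl substituent

The source may hold more compounds than are shown below. What is called first, only, known or untested is meant among the compounds shown, and "the series" means these compounds.

In a functional assay on HeLa cells (Homo sapiens) for inhibition, read by trypan blue exclusion, with a stated time of 72 h (on this read-out lower numbers stand for stronger inhibition of growth and higher numbers for weaker inhibition of growth), compound 1 `Cc1ncsc1C(=O)Oc1ccc(-c2[nH]c3ccccc3c2C)cc1` gives > 20000 nM, which is a limit of the assay and not a number. Going by the values given here, compound 2 `Cc1c(-c2ccc(O)cc2)n(CCCCOc2ccccc2)c2ccccc12` gives 11000 nM in this assay, the only true number so far. Compound 3 `Cc1c(-c2ccc(OC(=O)c3c[nH]cn3)cc2)[nH]c2ccccc12` keeps the core of compound 1 and carries 1H-imidazol-4-yl in place of 4-methyl-1,3-thiazol-5-yl on a carbonyl carbon. Among the compounds with values here, no measured step gives the size of this change, so the expectation is weakly founded. The expected at least 1.1-fold lower number from compound 1 to compound 3 (0.07 log units; that floor lies within the scatter) is small and points, if anywhere, towards stronger inhibition of growth. A second reading at the limit of the assay would not be surprising. For compound 3 the estimated value is 17000 nM, with an expected range from 8000 nM to 35000 nM.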

Compound 3, concentration for 50% growth inhibition: > 20000 nM
Compound 3 ended at the assay's limit; the forecaster's own chance of this, stated with the estimate: 50%; at least 1.1-fold (0.07 log units) between middle value and limit.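

No step can be read from compound 1 to compound 3, as each ends at a limit and not a number in this assay, and the two limits coincide: the limit of > 20000 nM in this assay, at which 2 of the 3 values shown sit. The compounds shown leave open whether 1H-imidazol-4-yl and 4-methyl-1,3-thiazol-5-yl on a carbonyl carbon differ at all in inhibition of growth.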